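Changing the group on the carbonyl carbon

The source may report more compounds than this note shows. Statements on the series, on what has been measured and on what is new or still open speak of the compounds shown alone.

Compound 1 `Cc1ccc(N(CCN2CCC(OCC(=O)O)CC2)C(=O)c2ccc(C(F)(F)F)cc2)cc1` gives > 10000 nM in a functional assay on a cell-free system (Platelet, plasma, Homo sapiens) for inhibition (on this read-out lower numbers stand for stronger inhibition and higher numbers for weaker inhibition), which is a limit and not a number. Compound 2 `O=C(O)COC1CCN(CCN(C(=O)c2ccc(C(F)(F)F)cc2)c2ccc(Cl)cc2)CC1` gives > 10000 nM in this assay, which is also a limit. The record so far is the limit of > 10000 nM in this assay, at which 2 of the 2 values shown sit. Among the compounds with values here, the only measured step, a step that the two limits leave unreadable from compound 1 to compound 2, therefore offers no size to carry forward, and it concerns a different place. Compound 3 `COc1cccc(C(=O)N(CCN2CCC(OCC(=O)O)CC2)c2ccc(C)cc2)c1OC` has 2,3-dimethoxyphenyl in place of 4-(trifluoromethyl)phenyl on a carbonyl carbon. Within the data shown here, no measured step covers this change. The expected step is a number no higher from compound 1 to compound 3 (the limit leaves the size open), an estimate with no measured size behind it in either direction. For compound 3 the estimated value is 10000 nM, expected within 2500 nM to 40000 nM.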

Compound 3, half-maximal inhibitory concentration: 1600 nM
Compound 3: middle estimate off by 6.3-fold (0.80 log units), on the high side, and the stated range ends above it.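

Placing 2,3-dimethoxyphenyl in place of 4-(trifluoromethyl)phenyl on the carbonyl carbon gives an at least 6.2-fold lower number from compound 1 to compound 3 (0.79 log units; beyond the scatter) in this assay, the first sign that this position can move the read-out. Within the data shown here, compound 3 is also the first compound here with a number, and the true size of the step stays unknown, as the record otherwise consists of limits: the limit of > 10000 nM in this assay, at which 2 of the 3 values shown sit.

Going by these compounds, it remains open whether both methoxy groups are needed, or whether a single methoxy or a hydroxy group would serve on this ring. On these data alone, whether 2,3-dimethoxyphenyl would have the same effect with the chloro of compound 2 is also open.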